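Series notes: removal of the carbonate ester side chain

A few compounds are considered here, and "the series" means these few. Any claim that something is new, unique, unknown or untested is made for them only; others in the source may bear on it.

The series shares one core carrying a propylthio group, a difluorophenyl-cyclopropylamine and a cyclopentane triol. Compound 1 `CCCSc1nc(N[C@@H]2C[C@H]2c2ccc(F)c(F)c2)c2nnn([C@@H]3C[C@H](OC(C)=O)[C@@H](O)[C@H]3O)c2n1` bears an acetate on the triol; in a functional assay on the whole organism (strain Sprague-Dawley) for inhibition, with Rattus norvegicus as the target, with a stated time of 0.5 h, at a dose of 5 mg/kg by the oral route (on this read-out lower numbers stand for less inhibition and higher numbers for more inhibition at the one dose given (going by the name of the read-out)), compound 1 gives "not determined" (no result reported). Compound 2 `CCCSc1nc(N[C@@H]2C[C@H]2c2ccc(F)c(F)c2)c2nnn([C@@H]3C[C@H](OC(=O)OCC)[C@@H](O)[C@H]3O)c2n1` carries an ethyl carbonate in the same position, and in this assay compound 2 gives 42.6%. Among the compounds with values here, compound 3 `CCCSc1nc(N[C@@H]2C[C@H]2c2ccc(F)c(F)c2)c2nnn([C@@H]3C[C@H](OCCOC(=O)OCC(C)C)[C@@H](O)[C@H]3O)c2n1` has a longer chain on the same oxygen, and in this assay compound 3 gives "not determined" (no result reported), so compound 3 stands on no number at all, and no step from it to any measured compound can be given.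

Compound 4 `CCCSc1nc(N[C@@H]2C[C@H]2c2ccc(F)c(F)c2)c2nnn([C@@H]3C[C@H](O)[C@@H](O)[C@H]3O)c2n1` is the free triol. The change from compound 3 to compound 4 is a hydrogen atom in place of a group of 10 heavy atoms (7 carbon, 3 oxygen; no ring), on an oxygen on a saturated carbon. Within the data shown here, no measured pair shows what such a change does in this assay; the only number in the set belongs to compound 2. The expectation is therefore anchored on compound 2 alone, which in this assay gives 42.6%; a value for compound 4 near that number is expected, with no direction claimed beyond the scatter, and with a wide range because the single point of reference is compound 2 with its 42.6%.

Compound 4 is estimated in this assay at 45%, expected between 20% and 70%.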

Compound 4, a percentage reported as inhibition, in the whole organism at one dose (the size of the read-out at that dose, not a potency): 45.7%
The estimate for compound 4 lay 0.7 percentage points below the measured number, and the stated range covers the measured number.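

In this assay, within the data shown here, the first readable pair at this position gives a number 3.1 percentage points higher from compound 2 to compound 4 (within the scatter) with hydrogen in place of ethoxycarbonyl on an oxygen on a saturated carbon. At the one oral dose and single time point, the read-out therefore does not separate the ethyl carbonate from the free hydroxyl, and the ethoxycarbonyl group is not required for a reading of this size within this pair. Nothing in the data shown accounts for the two readings lying so close together.

Compound 1 and compound 3 stand without a single number, so their steps to the free triol cannot be read, and the acetate and the longer carbonate-bearing chain remain unplaced at this oxygen. Also open, from the compounds shown here alone, is whether a group of another kind on this oxygen, such as an amine-bearing chain or a carboxylic acid, would leave the read-out within the scatter or move it, and whether the closeness seen for this one pair would hold at other doses or later times.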